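Cyclopropylamide on a Naphthyl Pyridine Acrylamide Series

The compounds below may be only part of what the source reports. "The series", "measured", "known", "first", "only" and "open" are said of these compounds alone.

The account concerns a small set of pyridine derivatives tested in a functional assay on HCT-116 cells (Homo sapiens) for inhibition, read by MTT assay, with a stated time of 72 h; on this read-out higher numbers stand for weaker inhibition of growth and lower numbers for stronger inhibition of growth. Compound 1 `CCOC(=O)/C=C/c1ccncc1-c1ccc2c(ccn2C)c1` is the strongest of the set: in this assay compound 1 gives 210 nM. Compound 2 `CNC(=O)/C=C/c1ccncc1-c1ccc2[nH]ccc2c1` reaches only a limit of the assay, > 30000 nM, and no number can be stated for it (the limit of > 30000 nM in this assay, at which 1 of the 3 values shown sits). Compound 3 `CNC(=O)CCc1ccncc1-c1ccc2ccccc2c1` in this assay gives 19300 nM, the highest of the two numbers given; compound 1 stands far below it, well beyond the usual scatter.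

Compound 4 `O=C(/C=C/c1ccncc1-c1ccc2ccccc2c1)NC1CC1` is not yet measured. It differs from compound 3 in one place (2-(cyclopropylcarbamoyl)ethenyl in place of 2-(methylcarbamoyl)ethyl on an aromatic carbon). Among the compounds with values here, no measured pair shows this change, so the size of the step is open. Within the data shown here, since compound 3 gives 19300 nM while compound 1, the only member with the ethenyl linker and a number, gives 210 nM, a step toward lower numbers for compound 4 is expected. Compound 2, which also carries a carbamoylethenyl group, reaches only a limit of the assay, so the expected step is modest and uncertain. The step from a 3.9-fold lower number from compound 3 to compound 4 (0.59 log units; beyond the scatter) is thus estimated as an improvement of moderate size. For compound 4 in this assay the estimate is 5000 nM, within 800 nM to 30000 nM.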

Compound 4, concentration for 50% growth inhibition: 6180 nM
For compound 4 the middle estimate is 1.2-fold (0.09 log units) below the measured one; measured number inside the range.
By their numbers in this assay, from the lowest: compound 1; then compound 4; then compound 3. At a limit, above all of these: compound 2.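

Within the data shown here, at the aromatic carbon opposite the ring nitrogen, ortho to a large group, the shared core now gives the first readable step of the set: in this assay there is a 3.1-fold lower number from compound 3 to compound 4 (0.49 log units; beyond the scatter). This shows that the side chain at this position can grow from 2-(methylcarbamoyl)ethyl to 2-(cyclopropylcarbamoyl)ethenyl, with a three-membered carbon ring and an added double bond and with the same count of hydrogen-bond donors and acceptors, and that the number falls rather than rises. Nothing measured here gives a reason for this step.

The change alters the linker and the group on the amide nitrogen together, so the share of each in the step cannot be told apart; that would take the ethenyl linker with a methyl amide, or the saturated linker with a cyclopropyl amide, on this same core. Also open, from the compounds shown here alone, is how this position would read with a larger ring or a longer chain on the amide nitrogen, or with a carboxylic acid in place of the amide.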